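A methyl moved around the thiophene ring

The source may report more compounds than this note shows. Statements on the series, on what has been measured and on what is new or still open speak of the compounds shown alone.

Compound 2, `Cc1ccc2nc(Cl)c(/C=C/C(=O)c3ccc(C)s3)cc2c1`, is one of two compounds with a number in a functional assay on HUVEC cells (Homo sapiens), read by BrdU incorporation, with a stated time of 72 h; a lower number here means a stronger inhibitor, a higher number a weaker inhibitor. In this assay compound 2 gives 128 nM. Compound 1, `Cc1cccc2cc(/C=C/C(=O)c3ccc(Cl)s3)c(Cl)nc12`, gives 116 nM in this assay, and the two numbers lie within the usual scatter of each other, so neither stands apart. Compound 3, `Cc1cc(C(=O)/C=C/c2cc3cccc(C)c3nc2Cl)c(C)s1`, has no result in this assay: for compound 3 the entry is "not determined" (no result reported). Compound 4, `Cc1csc(C(=O)/C=C/c2cc3cc(C)ccc3nc2Cl)c1`, differs from compound 2 in one place: 4-methylthiophen-2-yl in place of 5-methylthiophen-2-yl on a carbonyl carbon. Among the measured compounds shown here, no measured pair shows what such a change does here, so no direction can be read from the data. Compound 4 is therefore expected to stay within the scatter of compound 2, a step of a 1.2-fold higher number from compound 2 to compound 4 (0.07 log units; within the scatter). The estimate for compound 4 is 150 nM, between 60 nM and 400 nM.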

Compound 4, half-maximal inhibitory concentration: 106 nM
The estimate for compound 4 lay 1.4-fold (0.15 log units) above the measured number; low and high end bracket the measured number.
By their numbers in this assay, from the lowest: compounds 4, 1 and 2 (each within the scatter of the next).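

This pair is the only one shown in which a single change can be read: 4-methylthiophen-2-yl in place of 5-methylthiophen-2-yl on the carbonyl carbon gives a 1.2-fold lower number from compound 2 to compound 4 (0.08 log units; within the scatter) in this assay for the two compounds. At this level of scatter, the two methyl placements cannot be told apart. Nothing measured here offers a reason for this result. Still open, going by these compounds, is whether an amine or a carboxylic acid in place of the methyl would keep the number. A phenyl ring in place of the thiophene is equally untested in the compounds shown.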